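The compounds below may be only part of what the source reports. "The series", "measured", "known", "first", "only" and "open" are said of these compounds alone.

Measured so far:
compound 1, `Cc1cccc(-c2cnc(C(=O)CCCCCCc3ccccc3)o2)n1`: in an assay (Rattus norvegicus) for inhibition of Fatty-acid amide hydrolase 1 (Homo sapiens) (on this read-out higher numbers stand for weaker inhibition and lower numbers for stronger inhibition), compound 1 gives 3.3 nM
compound 2, `O=C(CCCCCCc1ccccc1)c1ncc(-c2cncnc2)o1`: in this assay compound 2 gives 22 nM

For the measured compounds named here, compound 2 stands at the higher of the two numbers; its only neighbour is compound 1, and the one recorded comparison, a 6.7-fold higher number from compound 1 to compound 2 (0.82 log units; beyond the scatter), separates them beyond the scatter.

Compound 3, `CN(C)C(=O)c1cnc(C(=O)CCCCCCc2ccccc2)o1`, is the next step from compound 2: dimethylcarbamoyl in place of pyrimidin-5-yl on an aromatic carbon. Going by the values given here, no measured step exchanges the six-membered aromatic ring at this position for an open-chain group such as dimethylcarbamoyl, so there is no direct precedent. Among the compounds with values here, the single step that bears on the position at all, a 6.7-fold higher number from compound 1 to compound 2 (0.82 log units; beyond the scatter), shows that an exchange of the group on this carbon can move the number by a modest amount and beyond the scatter, and that is taken as the scale of what to expect.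

On that basis the number for compound 3 is expected to rise further from compound 2, by roughly a 2.7-fold higher number from compound 2 to compound 3 (0.44 log units; beyond the scatter), with wide uncertainty in either direction. The estimate for compound 3 in this assay is 60 nM, with a range from 15 nM to 250 nM.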

Compound 3, inhibition constant: 2 nM
For compound 3 the middle estimate is 30-fold (1.48 log units) above the measured one; the whole stated range lies above it.
By their numbers in this assay, from the lowest: compounds 3 and 1 (each within the scatter of the next); then compound 2.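

On this carbon next to the ring oxygen, a ring is not required for strong inhibition in this assay: the step to dimethylcarbamoyl, which has no ring, is an 11-fold lower number from compound 2 to compound 3 (1.04 log units; beyond the scatter), a large change for a group with one heavy atom fewer than pyrimidin-5-yl. Measured against 6-methylpyridin-2-yl, the same exchange gives a 1.7-fold lower number from compound 1 to compound 3 (0.22 log units; within the scatter), so in these data the open-chain amide and that six-membered aromatic ring cannot be told apart, and pyrimidin-5-yl alone stands apart from both. The presence of an aromatic ring therefore does not set the number at this position, and nothing available explains why these three groups fall as they do.

As far as these compounds go, a primary amide, a carboxylic acid or a methyl ester on this carbon would help separate the contribution of the carbonyl from that of the two methyl groups of dimethylcarbamoyl, and that question remains open. Also open is whether the same pattern among these groups would hold with a shorter chain in place of the phenyl-ended chain of the shared core.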